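The source may hold more compounds than are shown below. What is called first, only, known or untested is meant among the compounds shown, and "the series" means these compounds.

In a functional assay on G-361 cells (Homo sapiens) for cytotoxicity, read by sulforhodamine B assay (a higher number here means that more compound is tolerated, a lower number that less compound is tolerated), compound 2 `CCCCNc1nc(C)nc2c1cnn2-c1ccccc1` gives > 100000 nM, which is a limit of the assay and not a number. Compound 1 `Cc1nc(NC(C)C)c2cnn(-c3ccccc3)c2n1` likewise stops at a limit, > 100000 nM. Compound 3 `CCNc1nc(C)nc2c1cnn2-c1ccccc1` also reaches only a limit, > 100000 nM. The steps among them, a step that the two limits leave unreadable from compound 1 to compound 2, a step that the two limits leave unreadable from compound 1 to compound 3 and a step that the two limits leave unreadable from compound 2 to compound 3, cannot be sized because of the limit of > 100000 nM in this assay, at which 3 of the 3 values shown sit. Among the measured compounds shown here, compound 4 `CCCCNc1nc(C(C)C)nc2c1cnn2-c1ccccc1` differs from compound 2 by isopropyl in place of methyl on an aromatic carbon, a place that none of the measured steps touches. With all three neighbours at the limit and no readable step to lean on, compound 4 is expected to show a step that the limit leaves unreadable from compound 2 to compound 4 that stays within the scatter. Compound 4 is therefore estimated at 150000 nM, with a range from 50000 nM to 500000 nM, and most likely reported again as a limit.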

Compound 4, concentration lethal to 50% of the cells: > 100000 nM
Compound 4 ended at the assay's limit (the forecaster's own chance of this, stated with the estimate: 85%); the middle value lies beyond the limit too.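

No step can be read from compound 2 to compound 4, because both values stop at a limit: the limit of > 100000 nM in this assay, at which 4 of the 4 values shown sit.

The compounds shown leave open how large the effect of any of these changes is in this assay.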